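Swapping a piperidine for its difluoro twin on compound 1

The source may hold more compounds than are shown below. What is called first, only, known or untested is meant among the compounds shown, and "the series" means these compounds.

Compound 1, with the structure `O=C(Nc1cccc(S(=O)(=O)C2CCCC2)c1)c1cccnc1N1CCCCC1`, is the weakest of three compounds measured in a functional assay on OVCAR-3 cells (Homo sapiens) for antiproliferative activity; on this read-out higher numbers stand for an effect only at larger amounts of compound and lower numbers for an effect already at smaller amounts. Compound 1 gives 5030 nM. The other two compounds, built on different cores, sit far lower: compound 2, `CC(C)(CO)Nc1ccc(C(=O)Nc2cccc(S(=O)(=O)NC3CCCC3)n2)c(N2CCC3(CC2)CC3)c1`, gives 32 nM, and compound 3, `CC(C)(C)NS(=O)(=O)c1cccc(NC(=O)c2ncc(NC(C)(C)CO)nc2N2CCC3(CC2)CC3)c1`, gives 110 nM. Both gaps to compound 1 lie beyond the usual scatter, so compound 1 is clearly the least potent of the three.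

Compound 4, `O=C(Nc1cccc(S(=O)(=O)C2CCCC2)c1)c1cccnc1N1CCC(F)(F)CC1`, keeps the whole of compound 1 except for one change: 4,4-difluoropiperidin-1-yl in place of piperidin-1-yl on an aromatic carbon. The group enters on an aromatic carbon of a six-membered aromatic ring with one nitrogen. Going by the values given here, no pair of measured compounds shows what this change alone does, and compounds 2 and 3 differ from compound 1 in too many places to help. Compound 4 is therefore expected to stay close to compound 1, with the step of a 1.3-fold lower number from compound 1 to compound 4 (0.10 log units; within the scatter) expected to be small and within the scatter. Compound 4 is estimated at 4000 nM, likely between 1500 nM and 11000 nM.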

Compound 4, half-maximal effective concentration: 4780 nM
Estimate against measurement, compound 4: 1.2-fold (0.08 log units) below, within the range that was stated.
By their numbers in this assay, from the lowest: compound 2; then compound 3; then compounds 4 and 1 (each within the scatter of the next).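

In this assay, the step of a 1.1-fold lower number from compound 1 to compound 4 (0.02 log units; within the scatter) shows that compound 1 and compound 4 cannot be told apart, so on an aromatic carbon next to the ring nitrogen, 4,4-difluoropiperidin-1-yl can stand in for piperidin-1-yl without a real shift in the read-out. The two fluorine atoms and the extra size they bring therefore give no measurable gain or loss on this core. No measurement is available to explain this result.

What the compounds shown leave open is whether this place accepts very different groups equally well, such as a dimethylamino group or a carboxylic acid in place of the ring. On these data alone, it also remains open whether the same swap would be just as silent on a different core.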